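Hydroxy to chloro on the aryl ketone of compound 2

This account rests on a few compounds, and the source may have more. Where it says the series, first, only, none or still open, it means among the compounds named here.

Among the compounds with values here, compound 2 `O=C(/C=C/c1cc2ccccc2[nH]c1=O)c1ccc(O)cc1` holds the only number in an ADME assay on SK-MEL-2 cells (Homo sapiens) for cytotoxicity, read by sulforhodamine B assay, with a stated time of 24 h; a lower number here means that less compound is tolerated, a higher number that more compound is tolerated: compound 2 gives 48300 nM. Compound 1 `COc1ccc(C(=O)/C=C/c2cc3ccccc3[nH]c2=O)cc1` sits at a limit of the assay, since in this assay compound 1 gives > 100000 nM, a limit and not a number. Within the data shown here, the single measured step, an at least 2.0-fold lower number from compound 1 to compound 2 (0.31 log units; beyond the scatter), therefore rests on the limit of > 100000 nM in this assay, at which 1 of the 2 values shown sits, and tells only that compound 2 is tolerated less than compound 1. Compound 3 `O=C(/C=C/c1cc2ccccc2[nH]c1=O)c1ccc(Cl)cc1` differs from compound 2 by chloro in place of hydroxy on an aromatic carbon. Among the measured compounds shown here, no measured step touches the hydroxy itself, so the one step on methyl removal gives no direct guide to a chloro; it only fixes the order of compound 1 and compound 2. For compound 3 in this assay a step in either direction beyond the scatter is possible, but none is predicted. Compound 3 is expected at 30000 nM, with a range of 10000 nM to 100000 nM, which means an expected step of a 1.6-fold lower number from compound 2 to compound 3 (0.21 log units; within the scatter).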

Compound 3, concentration lethal to 50% of the cells: 72600 nM
Beside the measured number, compound 3's estimate is 2.4-fold (0.38 log units) below it, and the stated range covers the measured number.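

In this assay, the change from 4-hydroxyphenyl to 4-chlorophenyl gives a 1.5-fold higher number from compound 2 to compound 3 (0.18 log units; within the scatter), so at this position, para to a large group, losing the hydrogen-bond donor and acceptor counted on the hydroxy does not move the number beyond the scatter. Chloro in place of methoxy gives an at least 1.3-fold lower number from compound 1 to compound 3 (0.13 log units; that floor lies within the scatter), so this step sets no order between the two compounds beyond the scatter. Compound 1 gives > 100000 nM, which is a limit and not a number, and this step rests on it: the limit of > 100000 nM in this assay, at which 1 of the 3 values shown sits.

Only hydroxy, methoxy and chloro are shown at this position, which leaves open how an amine or a carboxylic acid there would read in this assay. As far as these compounds go, the actual size of the step from methoxy to chloro also remains open.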